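Swapping a benzyl substituent and what it may mean for cytotoxicity

The source may hold more compounds than are shown below. What is called first, only, known or untested is meant among the compounds shown, and "the series" means these compounds.

Compound 1, `O=c1nc(N2CCC3(CCN(Cc4ccc(C(F)(F)F)cc4)CC3)CC2)sc2c([N+](=O)[O-])cc(C(F)(F)F)cc12`, is one of three compounds tested in an ADME assay on Vero cells (Chlorocebus sabaeus) for cytotoxicity, read by MTT assay, with a stated time of 72 h; a higher number here means that more compound is tolerated, a lower number that less compound is tolerated. Compound 1 gives 145000 nM, the second highest of the three numbers. Compound 2, `COc1ccc(CN2CC3(CCN(c4nc(=O)c5cc(C(F)(F)F)cc([N+](=O)[O-])c5s4)CC3)C2)cc1`, gives 78900 nM in this assay, a difference from compound 1 that lies within the scatter, so the two cannot be told apart. Compound 3, `O=c1nc(N2CCC3(CCN(Cc4ccc(F)cc4)C3)CC2)sc2c([N+](=O)[O-])cc(C(F)(F)F)cc12`, gives 811000 nM in this assay, a difference from compound 1 that lies beyond the scatter. No pair of these compounds differs in only one place, so no single step is shown between measured values.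

Compound 4, `O=c1nc(N2CCC3(CCN(Cc4cccc(F)c4)CC3)CC2)sc2c([N+](=O)[O-])cc(C(F)(F)F)cc12`, differs from compound 1 in one place: 3-fluorophenyl in place of 4-(trifluoromethyl)phenyl on a saturated chain carbon bound to an amine nitrogen in a ring. The value of compound 3 shows that a fluorophenyl group on a related core can go with a high number in this assay, but compound 3 also differs elsewhere, so this is only a hint. The step from compound 1 to compound 4 is expected to be a 1.7-fold higher number from compound 1 to compound 4 (0.24 log units; within the scatter), a modest rise that may stay within the scatter. Compound 4 is therefore estimated at 250000 nM, within a range from 90000 nM to 700000 nM.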

Compound 4, half-maximal cytotoxic concentration: 1400000 nM
The estimate for compound 4 lay 5.6-fold (0.75 log units) below the measured number; measured number outside the range, above it.
By their numbers in this assay, from the lowest: compounds 2 and 1 (each within the scatter of the next); then compounds 3 and 4 (each within the scatter of the next).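

In this assay, replacing 4-(trifluoromethyl)phenyl with 3-fluorophenyl on a saturated chain carbon bound to an amine nitrogen in a ring gives a 9.7-fold higher number from compound 1 to compound 4 (0.98 log units; beyond the scatter) and shows that this position can matter on its own. The earlier compounds shown here could not show this, since no two of them differed in only one place, whereas here the rest of the molecule stays the same. The data at hand offer no explanation for the size of this rise.

Since 4-(trifluoromethyl)phenyl and 3-fluorophenyl differ both in the group they carry and in where it sits, the compounds shown cannot separate these two parts of the change. From the compounds shown here alone, it also remains open how this position would respond to a different group on the ring, such as a nitrile or an amine.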